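This account rests on a few compounds, and the source may have more. Where it says the series, first, only, none or still open, it means among the compounds named here.

In a functional assay on BSC-1 cells (Cercopithecidae) for cytotoxicity (on this read-out lower numbers stand for stronger inhibition and higher numbers for weaker inhibition), compound 1 `COc1nc(N)c2ccn(COCCO)c2n1` gives > 100000 nM, which is a limit of the assay and not a number. Compound 2 `Nc1nc(O)nc2c1ccn2COCCO` in this assay gives > 100000 nM, likewise only a limit. Compound 3 `Nc1nc(Cl)nc2c1ccn2COCCO`, the starting point of the step followed here, gives > 100000 nM in this assay, again a limit rather than a number. The three steps among these compounds, a step that the two limits leave unreadable from compound 1 to compound 2, a step that the two limits leave unreadable from compound 1 to compound 3 and a step that the two limits leave unreadable from compound 2 to compound 3, cannot be read in size, because of the limit of > 100000 nM in this assay, at which 3 of the 3 values shown sit. Compound 4 `Nc1nc(N)c2ccn(COCCO)c2n1` has not been measured; it differs from compound 3 by amino in place of chloro on an aromatic carbon. Going by the values given here, none of the measured steps is readable, so none of them gives a size or direction for this one; all that is known is that the three measured compounds sit at the same limit. Compound 4 is therefore expected to remain at that limit as well, the step that the limit leaves unreadable from compound 3 to compound 4 being an estimate only. The estimate for compound 4 in this assay is 150000 nM, expected to lie within 50000 nM to 500000 nM.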

Compound 4, half-maximal inhibitory concentration: > 100000 nM
Compound 4: a limit, no number; the forecaster's own chance of this, stated with the estimate: 85%; the middle value is on the limit's open side.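

The steps from compound 4 to compounds 1, 2 and 3 cannot be read in size, as all four values are limits and not numbers: the limit of > 100000 nM in this assay, at which 4 of the 4 values shown sit.

The compounds shown leave open where each compound truly lies in this assay, and whether the groups exchanged on the aromatic carbon differ at all.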